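A few compounds are considered here, and "the series" means these few. Any claim that something is new, unique, unknown or untested is made for them only; others in the source may bear on it.

Working notes on the series. The shared core of compound 1 `NCC(=O)Nc1cc2cc[nH]c(=O)c2cc1Cl` carries an amide on the aromatic ring, and in an assay on isolated protein for inhibition of Rho-associated protein kinase 2 (Homo sapiens), read by a luciferase reporter (on this read-out lower numbers stand for stronger inhibition and higher numbers for weaker inhibition), compound 1 gives 120 nM, the highest of the three numbers recorded so far. Compound 2 `CC(C)(C)c1cccc(C2CNCC2C(=O)Nc2cc3cc[nH]c(=O)c3cc2Cl)c1` gives 11 nM and compound 3 `CC(C)c1cccc(C2CNCC2C(=O)Nc2cc3cc[nH]c(=O)c3cc2Cl)c1` gives 6 nM; both carry an amide whose carbonyl sits on a ring carbon in place of the open chain of compound 1, together with an aryl group on that ring, so their gap to compound 1 cannot be split between the two features. Among the compounds with values here, the one step measured within a single change, a 1.8-fold lower number from compound 2 to compound 3 (0.26 log units; within the scatter), concerns only the aryl substituent and does not bear on the amide side.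

Compound 4 `O=C(Nc1cc2cc[nH]c(=O)c2cc1Cl)[C@@H]1CCCNC1` is not yet measured. It differs from compound 1 by piperidin-3-yl in place of aminomethyl on a carbonyl carbon. Within the data shown here, no measured step isolates this exchange; what can be said is that compounds 2 and 3, both with the amide carbonyl bound to a ring carbon next to a saturated secondary amine, sit well below compound 1, though each also carries an aryl group that compound 4 lacks. A lowering of moderate size is therefore expected, a 3.0-fold lower number from compound 1 to compound 4 (0.48 log units; beyond the scatter), without the full drop seen for compound 2 or compound 3. For compound 4 the estimate in this assay is 40 nM, with a range from 10 nM to 160 nM.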

Compound 4, half-maximal inhibitory concentration: 47 nM
For compound 4 the middle estimate is 1.2-fold (0.07 log units) below the measured one; low and high end bracket the measured number.
By their numbers in this assay, from the lowest: compounds 3 and 2 (each within the scatter of the next); then compound 4; then compound 1.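

In this assay, within the data shown here, a 2.6-fold lower number from compound 1 to compound 4 (0.41 log units; beyond the scatter) is the only measured step at the carbonyl carbon itself, and it shows that piperidin-3-yl in place of aminomethyl lowers the number on its own, with no aryl group present. The step is modest but lies beyond the scatter, and the hydrogen-bond donor and acceptor counts of the two groups are the same; the exchange does add heavy atoms, a ring and a defined stereocentre all at once, and the step belongs to that exchange as a whole. Nothing available explains the step, and no measurement bears on its origin.

The compounds shown do not separate the ring from the added carbons: an open aminopentyl chain on the same carbonyl carbon would speak to that, and the opposite configuration of piperidin-3-yl would show whether the defined stereocentre matters. From the compounds shown here alone, how much an aryl group on piperidin-3-yl itself, such as 3-isopropylphenyl, would add to compound 4 also stays open.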